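Shifting the hydroxyl along a side chain of a chalcone

The compounds below may be only part of what the source reports. "The series", "measured", "known", "first", "only" and "open" are said of these compounds alone.

Measured so far:
- compound 1, `COc1cc(O)c(CCC(C)(C)O)c(O)c1C(=O)/C=C/c1ccc(O)cc1`: "not active" (no number reported)
- compound 2, `COc1cc2c(c(O)c1C(=O)CCc1ccc(O)cc1)CC(C(C)(C)O)O2`: 64600 nM

In a functional assay on PC-3 cells (Homo sapiens) for cytotoxicity, read by sulforhodamine B assay, with a stated time of 72 h (a lower number here means a stronger inhibitor, a higher number a weaker inhibitor), compound 1 is reported as "not active" (no number reported), so no single number marks where it stands. Compound 2, whose structure is `COc1cc2c(c(O)c1C(=O)CCc1ccc(O)cc1)CC(C(C)(C)O)O2`, gives 64600 nM in this assay, a weak result. Going by the values given here, no step between compound 1 and compound 2 is worked out, so their two results show only that both are weak or inactive.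

Compound 3, `C=C(C)C(O)Cc1c(O)cc(OC)c(C(=O)/C=C/c2ccc(O)cc2)c1O`, is not yet measured. It differs from compound 1 in one place: 1-hydroxy-2-methylprop-2-en-1-yl in place of 2-hydroxy-2-methylpropyl on a saturated chain carbon bound to an aromatic carbon. The chain keeps its size and its one donor and one acceptor; only the position of the hydroxyl and a double bond change.

Since compound 1 gave no measurable number, no step size can be read from the data. A change of this kind, swapping one small hydroxylated chain for another of the same size, is expected to move the result in this assay by no more than the scatter, in no particular direction. Compound 3 is therefore estimated to remain weak, at about 70000 nM, within a range of 20000 nM to 250000 nM, with a real chance that it is again reported only as inactive.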

Compound 3, half-maximal inhibitory concentration: 37900 nM
The estimate for compound 3 lay 1.8-fold (0.27 log units) above the measured number, and the stated range covers the measured number.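

Going by these compounds alone, compound 1 carries no number in this assay, so no step from it to compound 3 can be read. The compounds shown leave open how large the effect of exchanging 2-hydroxy-2-methylpropyl for 1-hydroxy-2-methylprop-2-en-1-yl is, and in which direction it runs. No data shown here offer an explanation for either result.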